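This account rests on a few compounds, and the source may have more. Where it says the series, first, only, none or still open, it means among the compounds named here.

Compound 1 `CN1CCC[C@@H]1Cn1nc(CC2CCCCC2)c2ccccc2c1=O` carries a cyclohexylmethyl group on the shared core. In an assay for binding affinity to Alpha-1A adrenergic receptor (Homo sapiens) (on this read-out higher numbers stand for weaker inhibition and lower numbers for stronger inhibition), compound 1 gives only a limit, > 1990 nM, and no number. That limit accounts for one of the two values shown (the limit of > 1990 nM in this assay, at which 1 of the 2 values shown sits). Compound 2 `CN1CCCCC(n2nc(Cc3ccc(Cl)cc3)c3ccccc3c2=O)C1` differs from compound 1 in its amine-bearing ring and in carrying a chlorine-bearing benzyl group in place of the cyclohexylmethyl. In this assay compound 2 gives 158 nM. Among the measured compounds shown here, no single step connects compound 1 and compound 2, so the two values stand side by side without a measured step between them. Compound 3 `CN1CCC[C@@H]1Cn1nc(Cc2cccc(F)c2)c2ccccc2c1=O` has not yet been measured. It differs from compound 1 in one place: 3-fluorophenyl in place of cyclohexyl on a saturated chain carbon bound to an aromatic carbon. Compound 1 stands only at a limit, so the step from it cannot be read in full. Even so, the expectation is that the step runs toward stronger binding, beyond the scatter, since compound 2 with its benzyl group reaches 158 nM. Compound 3 is therefore estimated at 400 nM in this assay, within a range from 100 nM to 2000 nM. This estimate means an expected step of an at least 4.9-fold lower number from compound 1 to compound 3 (0.69 log units; beyond the scatter).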

Compound 3, inhibition constant: 50.1 nM
The estimate for compound 3 lay 8.0-fold (0.90 log units) above the measured number; the measured number lies below the stated range.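

In this assay, the change from cyclohexyl to 3-fluorophenyl on a saturated chain carbon bound to an aromatic carbon gives an at least 39-fold lower number from compound 1 to compound 3 (1.59 log units; beyond the scatter). Compounds 1 and 2 differ in more than one place, so they could not isolate this position, whereas this step shows that changing this one group, with the rest of compound 1 held constant, is enough to shift the read-out well beyond the scatter. The step is itself only a bound, because compound 1 is recorded only at a limit and its full size cannot be read: the limit of > 1990 nM in this assay, at which 1 of the 3 values shown sits.

The step changes the saturated ring to an aromatic ring and adds fluorine together, so the compounds shown leave open how much of it would remain with a plain benzyl group, which carries no fluorine. They also leave open how this assay would respond to a chlorine atom or a methoxy group in place of the fluorine, or to a longer chain between the aromatic ring and the shared core.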